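Methoxy for fluoro on the aromatic carbon: compound 3

A few compounds are considered here, and "the series" means these few. Any claim that something is new, unique, unknown or untested is made for them only; others in the source may bear on it.

Going by the values given here, compound 2 `N=C(NCc1ccc(O)cc1)[C@@H]1CCC(=O)N1Cc1ccc(F)cc1` stands highest of the two numbers so far in a functional assay on SH-SY5Y cells (Homo sapiens) for cytotoxicity, read by MTT assay, with stated times of 8 h, 30 min and 12 h, tested at 0.5 uM (on this read-out higher numbers stand for a stronger effect at the one concentration tested and lower numbers for a weaker effect), where compound 2 gives 42%. Its nearest neighbour is compound 1 `N=C(NCc1ccc(O)cc1)[C@@H]1CCC(=O)N1Cc1ccc([N+](=O)[O-])cc1`, which in this assay gives 31.3%; the step of a number 10.7 percentage points higher from compound 1 to compound 2 (beyond the scatter) is modest but beyond the scatter. Compound 3 `COc1ccc(CN2C(=O)CC[C@H]2C(=N)NCc2ccc(O)cc2)cc1` differs from compound 2 at the same aromatic carbon: methoxy in place of fluoro on an aromatic carbon. Among the compounds with values here, no measured step exchanges fluoro for methoxy, so the only bearing step is that from nitro to fluoro, a number 10.7 percentage points higher from compound 1 to compound 2 (beyond the scatter), which shows that a change at this position can move the read-out modestly. With nothing to fix the direction, the expected step of a number 2 percentage points lower from compound 2 to compound 3 (within the scatter) is estimated to lie within the scatter. Compound 3 is accordingly expected to give about 40% in this assay, with a range from 25% to 55%.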

Compound 3, a percentage reported as activity, at one concentration (the size of the read-out at that concentration, not a potency): 20.5%
Estimate against measurement, compound 3: 19.5 percentage points above; the whole stated range lies above it.
By their numbers in this assay, from the lowest: compound 3; then compound 1; then compound 2.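

The position is more sensitive than the nitro-to-fluoro step alone suggested: in this assay, a number 21.5 percentage points lower from compound 2 to compound 3 (beyond the scatter), and the change lowers the read-out rather than leaving it within the scatter. Methoxy also falls short of nitro, with a number 10.8 percentage points lower from compound 1 to compound 3 (beyond the scatter), so the three groups separate into a clear order of fluoro, then nitro, then methoxy, with each pair beyond the scatter. Nothing available explains why the groups fall in this order.

Going by these compounds, whether chloro, an amine, a carboxylic acid or a longer alkoxy chain on this aromatic carbon would fall inside this span or outside it stays open. These numbers come from a single concentration, so they leave open whether the same order would hold across a range of concentrations.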